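Swapping Methoxy for Fluoro on a Phenyl Sulfonate

A few compounds are considered here, and "the series" means these few. Any claim that something is new, unique, unknown or untested is made for them only; others in the source may bear on it.

Compound 1 `CCN1CCN(c2ccc(S(=O)(=O)Oc3cccc(OC)c3)cc2)C1=O` and compound 2 `CCN1CCN(c2ccc(S(=O)(=O)Oc3cccc(F)c3)cc2)C1=O` share one core and differ only by fluoro in place of methoxy on an aromatic carbon. In a functional assay on MCF7 cells (Homo sapiens) for antiproliferative activity, read by sulforhodamine B assay, with a stated time of 48 h (a higher number here means a weaker inhibitor, a lower number a stronger inhibitor), compound 1 gives 14000 nM. Compound 2 reaches only a limit of the assay, > 100000 nM, namely (the limit of > 100000 nM in this assay, at which 1 of the 3 values shown sits). That gives an at least 7.1-fold higher number from compound 1 to compound 2 (0.85 log units; beyond the scatter). Compound 3 `CCCN1CCN(c2ccc(S(=O)(=O)Oc3ccc(OC)cc3)cc2)C1=O` rests on another core; how it differs from the core of compound 1 is not broken down here. In this assay compound 3 gives 20000 nM. Compound 4 `CCCN1CCN(c2ccc(S(=O)(=O)Oc3ccc(F)cc3)cc2)C1=O` differs from compound 3 by fluoro in place of methoxy on an aromatic carbon, the same kind of change, but here para to a large group instead of meta to it. A comparable step, a 7.5-fold higher number from compound 3 to compound 4 (0.88 log units; beyond the scatter), is expected because compound 3 starts at 20000 nM and the earlier change gave an at least 7.1-fold higher number from compound 1 to compound 2 (0.85 log units; beyond the scatter). Compound 4 is estimated at 150000 nM. That figure would likely come back as a limit.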

Compound 4, half-maximal inhibitory concentration: 33000 nM
Beside the measured number, compound 4's estimate is 4.5-fold (0.66 log units) above it, outside the stated range (below it).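

On the core of compound 3, fluoro in place of methoxy gives a 1.7-fold higher number from compound 3 to compound 4 (0.22 log units; within the scatter) in this assay. Set beside the earlier step, the same change does not carry over at one size: the same change on two cores in this assay, an at least 7.1-fold higher number (0.85 log units; beyond the scatter) from compound 1 to compound 2 and a 1.7-fold higher number (0.22 log units; within the scatter) from compound 3 to compound 4, at least 4.3-fold (0.63 log units) apart, beyond the scatter of two such steps This shows that the size of the step depends on the setting, but not which difference between the two pairs is responsible: the core, or the place of the change on the ring.

Going by these compounds, whether a chloro, methyl or amino group in the same place would behave like fluoro stays open. Also open, on these data alone, is how the swap would compare at both ring places on a single core.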